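Trifluoromethyl in place of methoxy: compound 3 to compound 4

This account rests on a few compounds, and the source may have more. Where it says the series, first, only, none or still open, it means among the compounds named here.

Measured in a functional assay on MCF7 cells (Homo sapiens) for antiproliferative activity, with a stated time of 5 days; a higher number here means a weaker inhibitor, a lower number a stronger inhibitor:
- compound 1 `CCCCc1ccc2[nH]c(-c3ccc(C(F)(F)F)cc3)c(/C=N/NC(=O)c3ccncc3)c2c1`: 100 nM
- compound 2 `CCCCc1ccc2[nH]c(-c3ccc(C(F)(F)F)cc3)c(/C=N/NC(=O)c3cccnc3)c2c1`: 260 nM
- compound 3 `CCCCc1ccc2[nH]c(-c3ccc(OC)cc3)c(/C=N/NC(=O)c3ccccn3)c2c1`: 160 nM

Compound 3, at 160 nM, lies within the scatter of each of the other two measured compounds. Compound 4 `CCCCc1ccc2[nH]c(-c3ccc(C(F)(F)F)cc3)c(/C=N/NC(=O)c3ccccn3)c2c1` carries trifluoromethyl in place of methoxy on an aromatic carbon, para to a large group (trifluoromethyl in place of methoxy on an aromatic carbon); the rest of compound 3 is kept.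

Within the data shown here, no measured step makes this exchange. Among the measured compounds shown here, the only step available, a 2.6-fold higher number from compound 1 to compound 2 (0.41 log units; beyond the scatter), is a modest one that changes pyridin-4-yl to pyridin-3-yl with the 4-(trifluoromethyl)phenyl group held constant. It shows that compounds carrying this group can differ beyond the scatter, but it says nothing direct about replacing methoxy. No direction can be assigned from these data, so no change beyond the scatter is expected in this assay. The estimated step is a 1.1-fold lower number from compound 3 to compound 4 (0.03 log units; within the scatter). For compound 4 the expected value is 150 nM, with an estimated range of 60 nM to 380 nM.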

Compound 4, half-maximal inhibitory concentration: 310 nM
For compound 4 the middle estimate is 2.1-fold (0.32 log units) below the measured one; the range from low to high includes it.
By their numbers in this assay, from the lowest: compounds 1, 3, 2 and 4 (each within the scatter of the next, the first and the last beyond it).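

In this assay, among these compounds, the first direct reading of this exchange, with the pyridin-2-yl carbonyl held, is a 1.9-fold higher number from compound 3 to compound 4 (0.29 log units; within the scatter) and so does not tell methoxy from trifluoromethyl on this aromatic carbon. With 4-(trifluoromethyl)phenyl held, a 1.2-fold higher number from compound 2 to compound 4 (0.08 log units; within the scatter) does not separate pyridin-2-yl from pyridin-3-yl, whereas a 3.1-fold higher number from compound 1 to compound 4 (0.49 log units; beyond the scatter) sets pyridin-4-yl apart from pyridin-2-yl, as it already stood apart from pyridin-3-yl. No measurement available here accounts for either reading.

Still open is whether the pyridine pattern holds in compounds with 4-methoxyphenyl, where only the pyridin-2-yl member is shown. Also open, on these data alone, is how an amine or a carboxylic acid on this aromatic carbon, or a longer chain on the shared core, would read in this assay against these compounds.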